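A second methoxy added to compound 2: what to expect

A few compounds are considered here, and "the series" means these few. Any claim that something is new, unique, unknown or untested is made for them only; others in the source may bear on it.

Going by the values given here, in a functional assay on K562 cells (Homo sapiens) for antiproliferative activity, read by MTT assay, with a stated time of 48 h (on this read-out higher numbers stand for weaker inhibition and lower numbers for stronger inhibition), compound 2 `COc1ccc(CN2C(=O)C(=O)c3cc(-c4ccc(OC)cc4)ccc32)cc1` gives 30 nM, the lowest of the three numbers known. Compound 1 `COc1ccc(-c2ccc3c(c2)C(=O)C(=O)N3Cc2cccc(Cl)c2)cc1` gives 200 nM, and compound 3 `COc1ccc(-c2ccc3c(c2)C(=O)C(=O)N3Cc2ccc(C#N)cc2)cc1` gives 380 nM. Every measured step alters the group on the saturated chain carbon bound to the amide-type nitrogen in a ring: a 6.7-fold lower number from compound 1 to compound 2 (0.82 log units; beyond the scatter) and a 13-fold higher number from compound 2 to compound 3 (1.10 log units; beyond the scatter), while a 1.9-fold higher number from compound 1 to compound 3 (0.28 log units; within the scatter). Compound 4 `COc1ccc(CN2C(=O)C(=O)c3cc(-c4ccc(OC)c(OC)c4)ccc32)cc1` differs from compound 2 elsewhere: methoxy in place of hydrogen on an aromatic carbon. Among the compounds with values here, no measured step touches that ring, so nothing known bears directly on this change. Compound 4 is therefore expected to stay close, with a 1.3-fold higher number from compound 2 to compound 4 (0.12 log units; within the scatter) lying within the scatter. The estimate for compound 4 in this assay is 40 nM, ranging from 12 nM to 130 nM.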

Compound 4, half-maximal inhibitory concentration: 260 nM
The estimate for compound 4 lay 6.5-fold (0.81 log units) below the measured number; the whole stated range lies below it.
By their numbers in this assay, from the lowest: compound 2; then compounds 1, 4 and 3 (each within the scatter of the next).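

In this assay, the change to 3,4-dimethoxyphenyl gives an 8.7-fold higher number from compound 2 to compound 4 (0.94 log units; beyond the scatter). The earlier compounds shown here varied only the group on the saturated chain carbon, whereas this result shows that the number also responds to a methoxy added to the other aromatic ring, ortho to a methoxy group. No evidence at hand accounts for this step.

From the compounds shown here alone, whether a hydroxyl, a fluorine or an amine at this place would act like methoxy remains open. So does whether this change would have a similar effect in compound 1 or compound 3.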